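The compounds below may be only part of what the source reports. "The series", "measured", "known", "first", "only" and "open" are said of these compounds alone.

Compound 1: `COc1ccc(-c2ccc(=O)n(CCC(=N)S)n2)cc1`; in a functional assay on the whole organism (stomach) with Rattus norvegicus as the target (on this read-out higher numbers stand for an effect only at larger amounts of compound and lower numbers for an effect already at smaller amounts), compound 1 gives > 100 mg/kg, which is a limit of the assay and not a number.
Compound 2: `N=C(S)CCn1nc(-c2ccc(Cl)c(Cl)c2)ccc1=O`; in this assay compound 2 gives 78.1 mg/kg.

Among the compounds with values here, compound 2 therefore stands as the only compound with a number in this assay. Within the data shown here, the value of compound 1 is a limit, (the limit of > 100 mg/kg in this assay, at which 1 of the 2 values shown sits), so no step between the two measured compounds can be stated, and only what the two values show can be said: compound 2 yields a number, compound 1 does not.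

Compound 3, `N=C(S)CCn1nc(-c2ccc(Cl)cc2)ccc1=O`, is not yet measured in this assay. It differs from compound 2 by hydrogen in place of chloro on an aromatic carbon, in words hydrogen in place of chloro on an aromatic carbon. Among the measured compounds shown here, since no measured step is available for guidance, the size of the change is expected to be modest, directed toward larger doses, and possibly beyond the scatter of repeated measurements, with a real chance that only a limit is reported. Compound 3 is expected to give about 110 mg/kg in this assay, with a range of 45 mg/kg to 260 mg/kg. This estimate corresponds to an expected step of a 1.4-fold higher number from compound 2 to compound 3 (0.15 log units; within the scatter).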

Compound 3, dose for half-maximal effect: > 100 mg/kg
Compound 3: no number, only a limit (the forecaster's own chance of this, stated with the estimate: 45%); the middle value does not contradict the limit.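

Within the data shown here, this is the first step in this assay that can be read at all: hydrogen in place of chloro on an aromatic carbon, ortho to a chloro group and meta to a large group, gives an at least 1.2-fold higher number from compound 2 to compound 3 (0.10 log units; that floor lies within the scatter). Compound 3 carries a limit and not a number, so this figure is only a floor, and the change is not shown to go beyond the scatter. The step between compound 1 and compound 3, chloro in place of methoxy, cannot be read, which leaves those two groups unranked and compound 2 as the only compound with a number: the limit of > 100 mg/kg in this assay, at which 2 of the 3 values shown sit.

Going by these compounds, how far the dose needed for compound 3 lies from that of compound 2 stays open, and so does whether the second chloro matters on this read-out at all. The compounds shown also do not tell what a fluoro, a methyl or an amine on that aromatic carbon would give, or what a longer chain on the core of compound 2 would do.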